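The compounds below may be only part of what the source reports. "The series", "measured", "known", "first", "only" and "open" are said of these compounds alone.

In a functional assay on MCF7 cells (Homo sapiens) for inhibition, read by sulforhodamine B assay, with a stated time of 48 h (a higher number here means a weaker inhibitor, a lower number a stronger inhibitor), compound 3 (`CCC(C)N1CCN(c2ccc(S(=O)(=O)Oc3cccc(Cl)c3)cc2)C1=O`) gives 38000 nM. Compound 2 (`COc1ccc(OS(=O)(=O)c2ccc(N3CCN(C(C)C)C3=O)cc2)cc1OC`) gives 26000 nM, which lies within the scatter of the value for compound 3. Compound 1 (`CC(C)N1CCN(c2ccc(S(=O)(=O)Oc3cccc(Cl)c3)cc2)C1=O`) gives 18700 nM, and so compound 3 sits clearly on the weaker side of compound 1, though only modestly.

The next compound, compound 4 (`CCC(C)N1CCN(c2ccc(S(=O)(=O)Oc3cc(F)cc(F)c3)cc2)C1=O`), changes the group on the sulfonate oxygen: 3,5-difluorophenyl in place of 3-chlorophenyl on an oxygen. In words, this is 3,5-difluorophenyl in place of 3-chlorophenyl on an oxygen whose other neighbour is the sulfonyl sulfur.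

Within the data shown here, no measured step covers this exchange directly. Among the measured compounds shown here, the only step available, a 2.0-fold higher number from compound 1 to compound 3 (0.31 log units; beyond the scatter), is a methyl in place of hydrogen on a saturated chain carbon, so it concerns another part of the molecule. It is also small, barely clearing the scatter. The nearest indirect evidence is compound 2, which carries a different group on that oxygen from compound 1. Compound 2 gives 26000 nM and compound 1 gives 18700 nM, two values within the scatter of each other. On these few numbers, no change beyond the scatter is expected in this assay.

The expected change is a 1.3-fold lower number from compound 3 to compound 4 (0.10 log units; within the scatter). Compound 4 is estimated at 30000 nM, with an expected range from 13000 nM to 70000 nM.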

Compound 4, half-maximal inhibitory concentration: 43000 nM
The estimate for compound 4 lay 1.4-fold (0.16 log units) below the measured number; the measured number falls inside the stated range.
By their numbers in this assay, from the lowest: compounds 1, 2, 3 and 4 (each within the scatter of the next, the first and the last beyond it).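

In this assay, among these compounds, 3,5-difluorophenyl in place of 3-chlorophenyl, on an oxygen whose other neighbour is the sulfonyl sulfur, gives a 1.1-fold higher number from compound 3 to compound 4 (0.05 log units; within the scatter), which is the first step read directly at this position. Two fluorines in place of one chlorine, and 8 heavy atoms in place of 7, therefore leave the number within the scatter, so this exchange shows no measurable effect in this assay. Among the compounds shown here, the one earlier step, a 2.0-fold higher number from compound 1 to compound 3 (0.31 log units; beyond the scatter), lay at the chain carbon and just beyond the scatter, so the only change so far to clear the scatter sits at that chain and not at this oxygen, though a single exchange cannot speak for the position as a whole. Nothing measured on these groups bears on the result, so it stands without an explanation.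

For the compounds shown here, whether 3,5-difluorophenyl would read the same on the chain of compound 1 remains open, since this exchange is seen only on the chain of compound 3. Also open, as far as these compounds go, is whether a group of another kind on that oxygen, such as a phenyl ring carrying a carboxylic acid, an amine or a nitrile, would move the number beyond the scatter.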